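Fluoro to chloro on the pendant phenyl ring

This account rests on a few compounds, and the source may have more. Where it says the series, first, only, none or still open, it means among the compounds named here.

Measured compounds:
compound 1 `N#Cc1cccc(S(=O)(=O)c2cnc3c(F)cccc3c2-c2cccc(Cl)c2)c1`, 1.11 mL/min
compound 2 `O=S(=O)(c1ccc(F)cc1)c1cnc2cc(F)ccc2c1-c1ccc(F)cc1`, 1.34 mL/min
compound 3 `N#Cc1cccc(S(=O)(=O)c2cnc3c(F)cccc3c2-c2cccc(F)c2)c1`, 0.34 mL/min

In an ADME assay on microsomes from liver (Homo sapiens) for metabolic stability, tested at 2.5 uM (a lower number here means slower removal, a higher number faster removal of the compound), compound 3 gives 0.34 mL/min and compound 1 gives 1.11 mL/min. The two share a core and differ by chloro in place of fluoro on an aromatic carbon, a change that made a 3.3-fold higher number from compound 3 to compound 1 (0.51 log units; beyond the scatter). Compound 2, on a different core, gives 1.34 mL/min in this assay; against compound 1 its number lies within the scatter, so no order between the two is claimed. The difference between the core of compound 2 and the core of compound 3 is not broken down here.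

Compound 4 `O=S(=O)(c1ccc(F)cc1)c1cnc2cc(F)ccc2c1-c1ccc(Cl)cc1` is not yet measured. It differs from compound 2 by chloro in place of fluoro on an aromatic carbon. Going by the values given here, this is the same kind of change as the one from compound 3 to compound 1, not the same: there the place reads meta to a large group, here it reads para to a large group. With one step of this kind in hand, and a different core and place, the direction is taken from it but the size is not carried over with confidence.

Compound 4 is expected to give 3 mL/min in this assay, that is an estimated step of a 2.2-fold higher number from compound 2 to compound 4 (0.35 log units; beyond the scatter), resting on the step from compound 3 to compound 1 and on compound 2 already standing at 1.34 mL/min. The expected range for compound 4 runs from 1.5 mL/min to 6 mL/min.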

Compound 4, intrinsic clearance in a liver preparation (reported as CLH), per the amount of preparation that the assay uses: 1.23 mL/min
Compound 4: middle estimate off by 2.4-fold (0.39 log units), on the high side, and the stated range ends above it.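

On the core of compound 2, the change from 4-fluorophenyl to 4-chlorophenyl gives a 1.1-fold lower number from compound 2 to compound 4 (0.04 log units; within the scatter) in this assay, so no shift can be read from this step. Set beside the earlier step, the same exchange of fluoro for chloro does not carry a fixed size from one core to the other in this series: the same change on two cores in this assay, a 3.3-fold higher number (0.51 log units; beyond the scatter) from compound 3 to compound 1 and a 1.1-fold lower number (0.04 log units; within the scatter) from compound 2 to compound 4, 3.6-fold (0.55 log units) apart, beyond the scatter of two such steps. This shows that a step seen on one core cannot be taken as a guide to the other, but it does not show what separates the two results, since the two pairs differ both in the core and in the place of the change on the pendant phenyl ring, and two steps give no general rule.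

On these data alone, it remains open whether the core or the place decides the outcome, which would take fluoro and chloro at one and the same place on both cores. As far as these compounds go, it also remains open how this assay responds on these cores when the halogen gives way to a different kind of group, such as methoxy, trifluoromethyl or an amine.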